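Tail extension from compound 2 to compound 4

The source may hold more compounds than are shown below. What is called first, only, known or untested is meant among the compounds shown, and "the series" means these compounds.

Of the compounds shown here, three sharing one core have been measured in an ADME assay on HT-29 cells (Homo sapiens) for inhibition, read by MTT assay, with a stated time of 72 h; a lower number here means a stronger inhibitor, a higher number a weaker inhibitor. Compound 1 `C=CC(=O)Nc1cccc(Nc2nc(N/N=C(\C)c3ccc(F)cc3)ncc2Cl)c1` gives 5050 nM, compound 2 `C=CC(=O)Nc1cccc(Nc2nc(N/N=C(\C)c3cccc(OC)c3)ncc2Cl)c1` gives 8990 nM, and compound 3 `C=CC(=O)Nc1cccc(Nc2nc(N/N=C(\C)c3ccncc3)ncc2Cl)c1` gives 12800 nM. Compound 2 stands second highest of the three numbers: a 1.8-fold higher number from compound 1 to compound 2 (0.25 log units; within the scatter) and a 1.4-fold higher number from compound 2 to compound 3 (0.15 log units; within the scatter), while a 2.5-fold higher number from compound 1 to compound 3 (0.40 log units; beyond the scatter). Compound 4 `COc1cccc(/C(C)=N/Nc2ncc(Cl)c(Nc3cccc(NC(=O)/C=C/CN(C)C)c3)n2)c1` keeps the 3-methoxyphenyl of compound 2 and differs only at the carbonyl: 3-(dimethylamino)prop-1-en-1-yl in place of vinyl on a carbonyl carbon. Going by the values given here, no measured step touches this carbonyl carbon; all three steps vary the group on the carbon with a double bond to nitrogen, so they give no guide to this change. With nothing pointing either way, the step of a 1.0-fold higher number from compound 2 to compound 4 (0.00 log units; within the scatter) is expected to stay within the scatter. Compound 4 is therefore estimated at 9000 nM, with a range of 3000 nM to 27000 nM.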

Compound 4, half-maximal inhibitory concentration: 3870 nM
Compound 4: the middle estimate sits 2.3-fold (0.37 log units) above what was measured; the measured number falls inside the stated range.
By their numbers in this assay, from the lowest: compounds 4, 1, 2 and 3 (each within the scatter of the next, the first and the last beyond it).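

The carbonyl carbon is a position that responds in this assay: 3-(dimethylamino)prop-1-en-1-yl in place of vinyl gives a 2.3-fold lower number from compound 2 to compound 4 (0.37 log units; beyond the scatter), the first step read at this place and one beyond the scatter. Nothing measured here bears on why the number drops.

Still open, as far as these compounds go, is whether the step belongs to the dimethylamino nitrogen or to the longer chain; a morpholine at the chain end, or a plain carbon chain without the nitrogen, would separate the two. Also open, from the compounds shown here alone, is whether the same change holds on the 4-fluorophenyl of compound 1.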